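Aryl Amine to Benzyl Amine on a Shared Core

This account rests on a few compounds, and the source may have more. Where it says the series, first, only, none or still open, it means among the compounds named here.

Measured in an in vitro assay on HEK-tsA201 cells for antagonist activity at Neuronal acetylcholine receptor; alpha4/beta2 (Homo sapiens), read by fluorescence and calcium flux; a higher number here means a weaker inhibitor, a lower number a stronger inhibitor:
compound 1 `CCCOc1ccc(C(=O)Nc2cccc(Cl)n2)cc1` — > 100000 nM
compound 2 `CCCOc1ccc(C(=O)Nc2cccc(Nc3ccc(OC)cc3)n2)cc1` — > 100000 nM

In this assay compound 1 gives > 100000 nM, which is a limit of the assay and not a number. Compound 2 gives > 100000 nM in this assay, likewise a limit. The step that the two limits leave unreadable from compound 1 to compound 2 cannot be read because the limit of > 100000 nM in this assay, at which 2 of the 2 values shown sit, holds both ends of it. Compound 2 therefore stands at the limit of this assay, and no number describes how far beyond it the compound lies.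

Compound 3 `CCCOc1ccc(C(=O)Nc2cccc(NCc3ccccc3)n2)cc1` differs from compound 2 in one place: benzyl in place of 4-methoxyphenyl on a nitrogen on an aromatic ring. Among the compounds with values here, the only measured step is the unreadable one from compound 1 to compound 2, so no measured step gives a size that bears on this change. With compound 2 sitting at the limit, compound 3 is expected to remain near that limit as well, and the step that the limit leaves unreadable from compound 2 to compound 3 is expected to be small or not readable. Compound 3 is estimated at 150000 nM in this assay, with a range from 30000 nM to 600000 nM.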

Compound 3, half-maximal inhibitory concentration: > 100000 nM
Compound 3 gave a limit, no number (the forecaster's own chance of this, stated with the estimate: 80%); the middle value lies beyond the limit too.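

Within the data shown here, no step involving compound 3 can be read, neither from compound 1 nor from compound 2, because all three compounds give a limit and not a number: the limit of > 100000 nM in this assay, at which 3 of the 3 values shown sit. The compounds shown leave open whether any group on the shared core other than chloro, (4-methoxyphenyl)amino or benzylamino would give a readable value in this assay.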